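The source may report more compounds than this note shows. Statements on the series, on what has been measured and on what is new or still open speak of the compounds shown alone.

Measured compounds:

- compound 1, `COc1ccc(-c2nc3cc(C(C)=O)ccc3[nH]2)c(OC)c1OC`: > 100000 nM
- compound 2, `Oc1ccc(-c2nc3cc(C(F)(F)F)ccc3[nH]2)cc1`: > 100000 nM
- compound 3, `CC(=O)Nc1ccc(-c2nc3cc(Cl)c(Cl)cc3[nH]2)cc1`: > 100000 nM

All three values come from an ADME assay on Vero cells (Chlorocebus sabaeus) for cytotoxicity; a higher number here means that more compound is tolerated, a lower number that less compound is tolerated. In this assay compound 1 gives > 100000 nM, which is a limit of the assay and not a number. Compound 2 likewise gives > 100000 nM, again only a limit. Compound 3 gives > 100000 nM, also a limit. Among the compounds with values here, compound 1 therefore stands where every measured value of the series stands, at the limit of > 100000 nM in this assay, at which 3 of the 3 values shown sit, and no step between measured compounds is available to show how any structural change moves this read-out.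

Compound 4, `COc1ccc(-c2nc3cc(C(F)(F)F)ccc3[nH]2)c(OC)c1OC`, differs from compound 1 in one place: trifluoromethyl in place of acetyl on an aromatic carbon. Within the data shown here, with no measured step to draw on and all three measured values sitting at the same limit, no change beyond the scatter is expected in this assay for this exchange. Compound 4 is expected at 100000 nM, with a range of 50000 nM to 300000 nM, most likely reported again as a limit. The step this implies, a number no higher from compound 1 to compound 4 (the limit leaves the size open), is an estimate of no change beyond the scatter.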

Compound 4, half-maximal cytotoxic concentration: 70000 nM
Estimate against measurement, compound 4: 1.4-fold (0.15 log units) above; measured number inside the range.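

In this assay, within the data shown here, compound 4 gives 70000 nM as a number, the only value shown that is not a limit. Trifluoromethyl in place of acetyl on this aromatic carbon gives an at least 1.4-fold lower number from compound 1 to compound 4 (0.15 log units; that floor lies within the scatter) and this is the only step available for this position, so the exchange cannot be read as a real loss of tolerance. The other values shown offer no number to set beside it: the limit of > 100000 nM in this assay, at which 3 of the 4 values shown sit.

From the compounds shown here alone, the true size of the step stays open, the value for compound 1 being only a limit of the assay. Also open, going by these compounds, is how an amine, a carboxylic acid or a longer chain on this aromatic carbon would move the read-out on the core of compound 1.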